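A Methoxy Swap in a Series at Its Limit

This account rests on a few compounds, and the source may have more. Where it says the series, first, only, none or still open, it means among the compounds named here.

In a functional assay on MM1.S cells (Homo sapiens) for cytotoxicity, read by MTT assay, with a stated time of 48 h (on this read-out lower numbers stand for stronger inhibition and higher numbers for weaker inhibition), compound 1 (`ClC1=C(Cl)C(Cl)=C(Cl)C1=NNC1CCCCC1`) returns only a limit, > 3000 nM. Compound 2 (`CC(C)(C)NN=C1C(Cl)=C(Cl)C(Cl)=C1Cl`) also returns only a limit, > 3000 nM. Compound 3 (`Cc1cccc(NN=C2C(Cl)=C(Cl)C(Cl)=C2Cl)c1`) is likewise known only as a limit, > 3000 nM. Going by the values given here, it therefore stands with the other two at the limit of > 3000 nM in this assay, at which 3 of the 3 values shown sit, and the series offers no measured step. Compound 4 (`COc1cccc(NN=C2C(Cl)=C(Cl)C(Cl)=C2Cl)c1`) has methoxy in place of methyl on an aromatic carbon, meta to a large group (methoxy in place of methyl on an aromatic carbon). In this assay, no step beyond the scatter in either direction is expected, and the estimated change is a step that the limit leaves unreadable from compound 3 to compound 4. The expected value for compound 4 is 3500 nM, with an estimated range from 1500 nM to 9000 nM.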

Compound 4, half-maximal inhibitory concentration: > 3000 nM
Compound 4: no number, only a limit; the forecaster's own chance of this, stated with the estimate: 75%; the middle value lies beyond the limit too.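

Going by these compounds alone, compound 3 and compound 4 are both known only as limits in this assay, so no step between them can be read. The compounds shown leave open what number any of them would give, and so what methoxy in place of methyl does here.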